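Swapping the chain end of compound 2

A few compounds are considered here, and "the series" means these few. Any claim that something is new, unique, unknown or untested is made for them only; others in the source may bear on it.

Of the compounds shown here, three have been tested in a functional assay on the whole organism (Tail, strain ICR) with Mus musculus as the target, in the tail flick test, with a stated time of 150 min, at a dose of 25 umol/kg by the oral route; on this read-out higher numbers stand for a stronger effect at the one dose given and lower numbers for a weaker effect. Compound 1 `CSCC[C@H](NC(=O)CN(c1ncnc2c1ncn2C1CCCCO1)C1CC1)C(=O)OCc1ccccc1` gives 17.5%, compound 2 `NC(=O)CC[C@H](NC(=O)CN(c1nc(Cl)nc2[nH]cnc12)C1CC1)C(=O)O` gives 11.4%, and compound 3 `NC(=O)CC[C@H](NC(=O)CN(c1nc(Cl)nc2[nH]cnc12)C1CC1)C(=O)OCc1ccccc1` gives 31.1%. Compound 2 has the lowest of the three numbers; compound 1 stands nearest to it, within the scatter, while compound 3 lies furthest away, beyond the scatter. For the measured compounds named here, the only single change measured so far is a number 19.7 percentage points higher from compound 2 to compound 3 (beyond the scatter), a change on an oxygen next to a carbonyl group.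

Compound 4 `NCCCC[C@H](NC(=O)CN(c1nc(Cl)nc2[nH]cnc12)C1CC1)C(=O)O` differs from compound 2 at another place: 2-aminoethyl in place of carbamoyl on a saturated chain carbon, three bonds along the chain from an amide-type nitrogen and a carbonyl carbon. The acid and the shared core stay untouched. Going by the values given here, no measured step covers this kind of change, so the data give no sign of whether it raises or lowers the number, and the expectation has to rest on compound 2 alone, with wide uncertainty. The expected step is a number 2.6 percentage points higher from compound 2 to compound 4 (within the scatter), nothing beyond the scatter. Compound 4 is therefore estimated at 14%, within a range from 0% to 32%.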

Compound 4, a percentage reported as activity, at one dose (the size of the read-out at that dose, not a potency): 11.6%
Estimate against measurement, compound 4: 2.4 percentage points above, within the range that was stated.
By their numbers in this assay, from the lowest: compounds 2, 4 and 1 (each within the scatter of the next); then compound 3.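

For the compounds shown here, this is the first measured step at this position, on a saturated chain carbon, three bonds along the chain from an amide-type nitrogen and a carbonyl carbon. In this assay the result is a number 0.2 percentage points higher from compound 2 to compound 4 (within the scatter), so with the free acid kept, carbamoyl and 2-aminoethyl cannot be told apart, whereas the step on the oxygen is larger, a number 19.7 percentage points higher from compound 2 to compound 3 (beyond the scatter), and lies beyond the scatter. Nothing measured here accounts for this result.

Going by these compounds, whether the same swap would also leave the number in place with the benzyl group on the oxygen, as in compound 3, remains open. Also open, on these data alone, is what a carboxylic acid or a guanidine at the end of the chain, or a longer chain, would give at this position.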